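This account rests on a few compounds, and the source may have more. Where it says the series, first, only, none or still open, it means among the compounds named here.

Working notes on the series, all values from a functional assay on HeLa cells (Homo sapiens) for antiproliferative activity, read by MTT assay, with a stated time of 72 h; a higher number here means a weaker inhibitor, a lower number a stronger inhibitor. Compound 1 (`COc1cc(C(=O)c2sc3ccccc3c2-c2ccc(F)cc2)cc(OC)c1OC`) gives 3000 nM in this test. Compound 2 (`COc1cc(C(=O)c2sc3ccccc3c2-c2ccc(C)cc2)cc(OC)c1OC`) gives 3700 nM and compound 3 (`COc1ccc(-c2c(C(=O)c3cc(OC)c(OC)c(OC)c3)sc3ccccc23)cc1`) gives 4200 nM on the same scale. Compound 1 thus stands within the scatter of both the others, and none of the three separates from the rest.

The step of interest leads to compound 4 (`COc1cc(C(=O)c2sc3ccccc3c2-c2ccc(SC)cc2)cc(OC)c1OC`). The change is methylsulfanyl in place of fluoro on an aromatic carbon in short, methylsulfanyl in place of fluoro on an aromatic carbon, para to a large group.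

Among the measured compounds shown here, three measured steps bear on it, all at that same place. Methyl in place of fluoro gives a 1.2-fold higher number from compound 1 to compound 2 (0.09 log units; within the scatter) and methoxy in place of fluoro gives a 1.4-fold higher number from compound 1 to compound 3 (0.15 log units; within the scatter) in the same series. Methoxy in place of methyl gives a 1.1-fold higher number from compound 2 to compound 3 (0.06 log units; within the scatter) as well. None of these replacements moves the number beyond the scatter, though methylsulfanyl itself has not been measured here, so the reading carries over only by analogy.

No step beyond the scatter is therefore expected in this assay, and no direction can be claimed. The expected step is a 1.3-fold higher number from compound 1 to compound 4 (0.10 log units; within the scatter) on this estimate. For compound 4 the estimated value is 3800 nM with an expected range from 1800 nM to 8000 nM in this test.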

Compound 4, half-maximal inhibitory concentration: 3500 nM
Compound 4: middle estimate off by 1.1-fold (0.04 log units), on the high side; the measured number falls inside the stated range.
By their numbers in this assay, from the lowest: compounds 1, 4, 2 and 3 (each within the scatter of the next).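

Replacing fluoro with methylsulfanyl gives a 1.2-fold higher number from compound 1 to compound 4 (0.07 log units; within the scatter) and replacing methoxy with it gives a 1.2-fold lower number from compound 3 to compound 4 (0.08 log units; within the scatter) while replacing methyl with it gives a 1.1-fold lower number from compound 2 to compound 4 (0.02 log units; within the scatter) in this assay on this aromatic carbon, para to a large group. The earlier compounds shown here covered only fluoro, methyl and methoxy at this place, and the series now shows that a group holding sulfur also stays within the scatter of all three, so the four compounds cannot be put in any order here. No evidence at hand accounts for this flat reading.

The four groups shown leave open whether this place can shift the number at all, since every step seen so far stays within the scatter, and a group of another kind, such as an amine, a carboxylic acid or a longer chain, could still behave differently. From the compounds shown here alone, it also remains open whether the sulfur of methylsulfanyl matters in any way of its own, as a single compound with that group cannot separate it from the other groups.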